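Replacing the 3-methoxyphenyl group of compound 2

The source may hold more compounds than are shown below. What is called first, only, known or untested is meant among the compounds shown, and "the series" means these compounds.

In a functional assay on K562 cells (Homo sapiens) for antiproliferative activity, read by MTT assay, with a stated time of 48 h (on this read-out higher numbers stand for weaker inhibition and lower numbers for stronger inhibition), compound 1 `COc1ccc(-c2ccc3c(c2)C(=O)C(=O)N3Cc2ccc(C)cc2)cc1` gives 270 nM and compound 2 `COc1ccc(CN2C(=O)C(=O)c3cc(-c4cccc(OC)c4)ccc32)cc1` gives 100 nM, the lower of the two numbers and a gap beyond the usual scatter. Compound 3 `COc1ccc(CN2C(=O)C(=O)c3cc(-c4ccc(C)cc4)ccc32)cc1` has not yet been measured. It differs from compound 2 in one place: 4-methylphenyl in place of 3-methoxyphenyl on an aromatic carbon, (4-methylphenyl in place of 3-methoxyphenyl on an aromatic carbon). The two measured compounds differ from each other in more than one place, so neither gives a direct reading of this change. Their values span only from compound 1 at 270 nM to compound 2 at 100 nM, which suggests a modest shift at most. The expected change is a 1.5-fold higher number from compound 2 to compound 3 (0.18 log units; within the scatter), a slight rise in the number that is not expected to pass beyond the scatter. For compound 3 the estimated value is 150 nM, within an expected range of 50 nM to 450 nM.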

Compound 3, half-maximal inhibitory concentration: 400 nM
Compound 3: the middle estimate sits 2.7-fold (0.43 log units) below what was measured, and the stated range covers the measured number.
By their numbers in this assay, from the lowest: compound 2; then compounds 1 and 3 (each within the scatter of the next).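

Within the data shown here, the swap of 3-methoxyphenyl for 4-methylphenyl on this aromatic carbon is the first change here that can be read in one place, and in this assay it gives a 4.0-fold higher number from compound 2 to compound 3 (0.60 log units; beyond the scatter). This shows that the group at this position matters for the read-out, and that the 3-methoxyphenyl of compound 2 is the better of the two groups compared at this position. Nothing given here accounts for the difference.

The step alters both the substituent and its place on the phenyl ring, so the compounds shown cannot separate the two contributions. As far as these compounds go, how a plain phenyl, or a phenyl ring carrying an amine or a carboxylic acid, would behave at this position also remains open.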